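The source may hold more compounds than are shown below. What is called first, only, known or untested is meant among the compounds shown, and "the series" means these compounds.

Compound 2 `CC(C(=O)N1CCN(c2ccccc2)CC1)N1C(=O)CCC1=O` is the unsubstituted member of the pair measured so far. In a functional assay on the whole organism (strain Swiss) with Mus musculus as the target, in the maximal electroshock model, with a stated time of 0.25 h, at a dose of 300 mg/kg by the intraperitoneal route (a lower number here means a weaker effect, a higher number a stronger effect of the compound at the dose given), compound 2 gives 100%, the highest of the two numbers in hand; the nearest is compound 1 `COc1cccc(N2CCN(C(=O)C(C)N3C(=O)CCC3=O)CC2)c1`, which in this assay gives 75%. Among the compounds with values here, the only step between measured compounds is the removal of the methoxy group, a number 25 percentage points higher from compound 1 to compound 2 (beyond the scatter), hydrogen in place of methoxy on an aromatic carbon.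

Compound 3 `CC(C(=O)N1CCN(c2ccc(C(F)(F)F)cc2)CC1)N1C(=O)CCC1=O` has yet to be measured. It differs from compound 2 by trifluoromethyl in place of hydrogen on an aromatic carbon. Within the data shown here, no measured pair carries this change, so the one step in hand bears on it only indirectly: there, a substituent on the aromatic ring went with the lower number and its removal with the higher. Compound 2 also stands at a value that leaves no room upward in this assay. A downward step of modest size, or none beyond the scatter, is therefore expected. The step from compound 2 to compound 3 estimated here is a number 15 percentage points lower from compound 2 to compound 3 (beyond the scatter). For compound 3 the estimate in this assay is 85%, with an expected range from 60% to 100%.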

Compound 3, a percentage reported as activity, at one dose (the size of the read-out at that dose, not a potency): 25%
Compound 3: the middle estimate sits 60 percentage points above what was measured; measured number outside the range, below it.
By their numbers in this assay, from the lowest: compound 3; then compound 1; then compound 2.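

Trifluoromethyl in place of hydrogen on an aromatic carbon, para to a large group, gives in this assay a number 75 percentage points lower from compound 2 to compound 3 (beyond the scatter) and thus shows that this place on the aromatic ring is far from indifferent to what it carries. Methoxy in compound 1 already went with a lower number, with a number 25 percentage points higher from compound 1 to compound 2 (beyond the scatter) on its removal, and with compound 3 both substituted members of this small set now lie lower than the unsubstituted compound 2, with no compound shown going against that. Nothing at hand bears on why the number falls so far on this change.

The compounds shown leave open whether the drop belongs to trifluoromethyl itself or would follow any group at this place, which a single fluorine atom, a methyl group or a methoxy group at the same carbon would help to separate. They also leave open how compound 3 behaves at other doses or other times, since the read-out here is the size of the effect at one dose and one stated time, not a potency.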